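Amide variation on a benzimidazole-type translocator protein ligand

The compounds below may be only part of what the source reports. "The series", "measured", "known", "first", "only" and "open" are said of these compounds alone.

Compound 1 `CCN(CC)C(=O)c1nc2ccccc2n1Cc1ccc(Cl)cc1` is measured in an assay on membranes from HEK293 cells for displacement of a labelled ligand from Translocator protein (Homo sapiens), read by scintillation counting, with a stated time of 90 min (on this read-out higher numbers stand for weaker inhibition and lower numbers for stronger inhibition), and gives only a limit of the assay, > 10000 nM. Compound 2 `CCN(CC)C(=O)c1nc2ccccc2n1Cc1ccc(OC)nc1` likewise reaches only a limit in this assay, > 10000 nM, so the step that the two limits leave unreadable from compound 1 to compound 2 cannot be read, since both values sit at the limit of > 10000 nM in this assay, at which 2 of the 2 values shown sit. Compound 3 `CN(Cc1ccccc1)C(=O)c1nc2ccccc2n1Cc1ccc(Cl)cc1` differs from compound 1 by benzyl(methyl)amino in place of diethylamino on a carbonyl carbon. No measured step touches this position, so no size or direction can be drawn from the shown steps. The estimate for compound 3 in this assay is 3000 nM, between 300 nM and 30000 nM, expected to correspond to a step of an at least 3.3-fold lower number from compound 1 to compound 3 (0.52 log units; beyond the scatter).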

Compound 3, inhibition constant: > 10000 nM
Compound 3 gave a limit, no number (the forecaster's own chance of this, stated with the estimate: 45%); middle value at least 3.3-fold (0.52 log units) from the limit.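

The step from compound 1 to compound 3 cannot be read, since both values are limits of the assay: the limit of > 10000 nM in this assay, at which 3 of the 3 values shown sit.

The compounds shown leave open which amide group, if any, would give a measurable number in this assay.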